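The source may hold more compounds than are shown below. What is called first, only, known or untested is meant among the compounds shown, and "the series" means these compounds.

Three compounds share one core and differ only in the group on a saturated ring carbon. Compound 1 `Cc1cc(C)c(S(=O)(=O)N2CCC(N3CCN(C)CC3)CC2)c(C)c1` carries a 4-methylpiperazin-1-yl there, and in a functional assay on DLD-1 cells (Homo sapiens) for antiproliferative activity, read by CellTiter-Glo, with a stated time of 72 h (a lower number here means a stronger inhibitor, a higher number a weaker inhibitor), compound 1 gives 1100 nM. Compound 2 `Cc1cc(C)c(S(=O)(=O)N2CCC(N3CCCCCC3)CC2)c(C)c1` carries an azepan-1-yl, and in this assay compound 2 gives 5.3 nM. Compound 3 `CCCC(=O)NC1CCN(S(=O)(=O)c2c(C)cc(C)cc2C)CC1` carries a (propylcarbonyl)amino. In this assay compound 3 reaches only the limit of > 5000 nM, so no number is known for it, (the limit of > 5000 nM in this assay, at which 1 of the 3 values shown sits). Compound 3 therefore stands at the weak end of the three, since the change an at least 940-fold higher number from compound 2 to compound 3 (2.97 log units; beyond the scatter) and the change an at least 4.5-fold higher number from compound 1 to compound 3 (0.65 log units; beyond the scatter) both run toward weaker inhibition.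

Compound 4 `Cc1cc(C)c(S(=O)(=O)N2CCC(C3OCC(C)CO3)CC2)c(C)c1` is not yet measured. It differs from compound 3 in that (a group of 7 heavy atoms (5 carbon, 2 oxygen; one six-membered non-aromatic ring with 2 hetero atoms) in place of a group of 6 heavy atoms (4 carbon, 1 nitrogen, 1 oxygen; no ring), on a saturated ring carbon). Neither the leaving nor the entering group is an azepan-1-yl or a 4-methylpiperazin-1-yl, the two groups that gave the measured numbers. Among the compounds with values here, the measured steps give no direct guide to this exchange; they show only that compound 3 sits at the limit. Compound 4 is therefore expected to stay near that limit, with the estimated step of a number no higher from compound 3 to compound 4 (the limit leaves the size open) not beyond the scatter. The estimate for compound 4 in this assay is 5000 nM, within a range from 1500 nM to 20000 nM.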

Compound 4, half-maximal inhibitory concentration: > 5000 nM
Compound 4 was reported as a limit; the forecaster's own chance of this, stated with the estimate: 55%; the middle value sits exactly at the limit.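

In this assay compound 4 also gives only a limit, > 5000 nM, not a number, so the step from compound 3 cannot be read: the limit of > 5000 nM in this assay, at which 2 of the 4 values shown sit A ring on this saturated ring carbon is therefore not enough for a measured number, since the group in compound 4 has the same count of 7 heavy atoms as the azepan-1-yl and the 4-methylpiperazin-1-yl, yet the data show an at least 940-fold higher number from compound 2 to compound 4 (2.97 log units; beyond the scatter) and an at least 4.5-fold higher number from compound 1 to compound 4 (0.65 log units; beyond the scatter). Among the four compounds, the two with measured numbers are those that carry a ring attached through its nitrogen. The compounds shown leave open where a piperidin-1-yl or a dimethylamino group would fall in this series. They also leave open whether an azepan-1-yl carrying a methyl group would keep the low number of compound 2.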